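A Methyl on the Carboxyphenyl Ring of Compound 2

This account rests on a few compounds, and the source may have more. Where it says the series, first, only, none or still open, it means among the compounds named here.

Compound 2 `Cc1c(OCCCCOc2ccc(C(=O)O)cc2)ccc(C(=O)CC2CCCC2)c1O` was tested in an assay on HEK293 cells for positive allosteric modulation of metabotropic glutamate receptor 3 (Rattus norvegicus), read by thallium flux, with a stated time of 2.5 min (a higher number here means that more compound is needed for the effect, a lower number that less compound is needed), and its result is only a limit, > 10000 nM, so no single number is known for it. Its relative compound 1 `Cc1c(OCCCCOc2ccc(C(=O)O)cc2)ccc(C(=O)CC(C)C)c1O` gives 2720 nM in this assay; the step of an at least 3.6-fold higher number from compound 1 to compound 2 (0.56 log units; beyond the scatter) came with cyclopentyl in place of isopropyl on a saturated chain carbon bound to a carbonyl carbon. Compound 3 `CCC(=O)c1ccc(OCCCCOc2cccc(C(=O)O)c2C)c(C)c1O` shows "not determined" (no result reported) in this assay. Compound 4 `Cc1cc(C(=O)O)ccc1OCCCCOc1ccc(C(=O)CC2CCCC2)c(O)c1C` differs from compound 2 by methyl in place of hydrogen on an aromatic carbon, the entering methyl sitting ortho to a large group and meta to a carboxy group. Among the measured compounds shown here, no measured step concerns such a change, so no shift beyond the scatter in this assay is expected, and a limit may recur. Compound 4 is estimated at 12000 nM, within 5000 nM to 30000 nM. The expected step is a step that the limit leaves unreadable from compound 2 to compound 4.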

Compound 4, half-maximal effective concentration: > 10000 nM
Compound 4 gave a limit, no number; the forecaster's own chance of this, stated with the estimate: 70%; the middle value lies beyond the limit too.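

Among the compounds shown here, compound 2 and compound 4 each give only a limit, not a number, so no step between them can be read. The compounds shown leave open whether 4-carboxy-2-methylphenyl in place of 4-carboxyphenyl changes the concentration needed at all.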